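Working notes: the step from compound 2 to compound 4

A few compounds are considered here, and "the series" means these few. Any claim that something is new, unique, unknown or untested is made for them only; others in the source may bear on it.

Of the compounds shown here, three sharing one core have been read in a functional assay on MCF7 cells (Homo sapiens) for cytotoxicity, read by MTT assay, with a stated time of 72 h; on this read-out lower numbers stand for stronger inhibition and higher numbers for weaker inhibition. Compound 1 `CCC(C)=C1C(=O)N(c2ccc(Cl)cc2)N(c2ccc(Cl)cc2)C1=O` gives 41600 nM, compound 2 `O=C1C(=Cc2ccc(Br)cc2)C(=O)N(c2ccc(Cl)cc2)N1c1ccc(Cl)cc1` gives 30400 nM and compound 3 `CC(=C1C(=O)N(c2ccc(Cl)cc2)N(c2ccc(Cl)cc2)C1=O)c1ccc(O)cc1` gives 76500 nM. Compound 2 stands within the scatter of compound 1, and only its gap to compound 3 lies beyond the scatter, with compound 3 reading higher.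

For the measured compounds named here, compound 4 `COc1ccccc1C=C1C(=O)N(c2ccc(Cl)cc2)N(c2ccc(Cl)cc2)C1=O` has not yet been read. It has 2-methoxyphenyl in place of 4-bromophenyl on a double-bonded chain carbon bound to a double-bonded ring carbon.

Going by the values given here, one measured step bears on this change, and only loosely. With 4-hydroxyphenyl in place of ethyl on a double-bonded chain carbon, the series shows a 1.8-fold higher number from compound 1 to compound 3 (0.26 log units; within the scatter). Among the compounds with values here, no measured step exchanges one substituted phenyl for another, so the data offer no direct precedent and no direction. With that single step as the guide, no step beyond the scatter is expected in this assay. Expressed as a step, the expectation is a 1.2-fold higher number from compound 2 to compound 4 (0.06 log units; within the scatter). The estimate for compound 4 is 35000 nM, with an expected range from 15000 nM to 75000 nM.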

Compound 4, half-maximal inhibitory concentration: 26300 nM
Compound 4: the middle estimate sits 1.3-fold (0.12 log units) above what was measured; measured number inside the range.
By their numbers in this assay, from the lowest: compounds 4, 2, 1 and 3 (each within the scatter of the next, the first and the last beyond it).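

In this assay the exchange of 4-bromophenyl for 2-methoxyphenyl on a double-bonded chain carbon bound to a double-bonded ring carbon gives a 1.2-fold lower number from compound 2 to compound 4 (0.06 log units; within the scatter) and so stays within the scatter. For the compounds shown here, this is the first measured step that exchanges one substituted phenyl for another, and it shows that this position accepts a change from a bromine-bearing ring to a ring with a methoxy group and one hydrogen-bond acceptor without a step beyond the scatter in this read-out. No measurement at hand accounts for the absence of a larger step, so the result stands as an observation on this one pair of compounds.

The change alters both the substituent and its place on the phenyl ring, so this pair cannot separate the two, and 4-methoxyphenyl or 2-bromophenyl would be needed to tell them apart. On these data alone, whether the tolerance extends beyond these two groups also remains open, for instance to an aminophenyl or a carboxylic acid on the phenyl ring at the same position.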